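The source may report more compounds than this note shows. Statements on the series, on what has been measured and on what is new or still open speak of the compounds shown alone.

Working notes on the series. The shared core of compound 3 `CN(Cc1ccccc1)C(=O)CNC(=O)c1ccc(S(C)(=O)=O)c([N+](=O)[O-])c1` is kept throughout; the set varies the amine on the carbonyl carbon and the substituent on the aromatic ring. Within the data shown here, in an assay on isolated protein for inhibition of thyroid hormone receptor beta (Homo sapiens), read by fluorescence polarization (a higher number here means a weaker inhibitor, a lower number a stronger inhibitor), compound 3 gives 39000 nM, the only number among the values at hand. Compound 1 `CN(Cc1cccc(F)c1)C(=O)CNC(=O)c1ccc(S(C)(=O)=O)c([N+](=O)[O-])c1` reaches only a limit in this assay, at > 60000 nM. Compound 2 `CN1CCN(C(=O)CNC(=O)c2ccc(S(C)(=O)=O)c([N+](=O)[O-])c2)CC1` likewise reaches only a limit in this assay, at > 60000 nM. The steps of an at least 1.5-fold lower number from compound 1 to compound 3 (0.18 log units; that floor lies within the scatter) and an at least 1.5-fold lower number from compound 2 to compound 3 (0.18 log units; that floor lies within the scatter) are therefore floors only, because both starting points sit at the limit of > 60000 nM in this assay, at which 2 of the 3 values shown sit.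

Compound 4 `CC(C)N(C(=O)CNC(=O)c1ccc(S(C)(=O)=O)c([N+](=O)[O-])c1)C(C)C` is not yet measured. diisopropylamino in place of benzyl(methyl)amino on a carbonyl carbon The change sits on the same carbonyl carbon as the change in an at least 1.5-fold lower number from compound 2 to compound 3 (0.18 log units; that floor lies within the scatter), and that step is the one that bears on it; the aromatic-ring step an at least 1.5-fold lower number from compound 1 to compound 3 (0.18 log units; that floor lies within the scatter) does not. Both compounds that lack an aromatic ring on that amine or carry another change have so far given only limits, so a step in the weaker direction, back toward the limit, is expected here, though its size cannot be pinned down from floors alone. The expected step is a 2.1-fold higher number from compound 3 to compound 4 (0.31 log units; beyond the scatter), and it is an estimate only. Compound 4 is therefore expected to give 80000 nM in this assay, with a range from 30000 nM to 250000 nM, and most likely to be reported as a limit rather than a number.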

Compound 4, half-maximal inhibitory concentration: > 60000 nM
Compound 4 was reported as a limit (the forecaster's own chance of this, stated with the estimate: 65%); the middle value lies beyond the limit too.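

On the carbonyl carbon, diisopropylamino in place of benzyl(methyl)amino gives an at least 1.5-fold higher number from compound 3 to compound 4 (0.18 log units; that floor lies within the scatter), which is a floor only and does not establish a real loss. Compound 4 gives only a limit in this assay, at > 60000 nM, so a branched amine with no ring now joins the 4-methylpiperazin-1-yl of compound 2 in giving no number. Among the amines shown on this carbonyl carbon, only benzyl(methyl)amino in compound 3 gives a number, though compound 1 goes against any simple link to an aromatic ring, since it keeps that ring with a fluoro substituent and still sits at the limit: the limit of > 60000 nM in this assay, at which 3 of the 4 values shown sit.

On these data alone, the step between compound 2 and compound 4 cannot be read, as both values are limits, and the true size of the step from compound 3 remains unknown. As far as these compounds go, it also remains open whether a smaller amine such as dimethylamino, or a longer chain between the nitrogen and the phenyl ring as in methyl(2-phenylethyl)amino, would give a number in this assay at all.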